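This account rests on a few compounds, and the source may have more. Where it says the series, first, only, none or still open, it means among the compounds named here.

Compound 1, with the structure `Nc1ccccc1/C=C/c1cccc(O)c1`, is tested in a functional assay on HT-29 cells (Homo sapiens) for inhibition, read by MTT assay, with a stated time of 2 days (a lower number here means a stronger inhibitor, a higher number a weaker inhibitor), where compound 1 gives 30 ug/mL. Compound 2, `COc1ccccc1/C=C/c1cccc(O)c1`, differs from it by the change (methoxy in place of amino on an aromatic carbon); in this assay compound 2 gives 17 ug/mL, so that the change made the step of a 1.8-fold lower number from compound 1 to compound 2 (0.25 log units; within the scatter). Compound 3, `Nc1ccc(/C=C/c2cccc(O)c2)cc1`, shares its atoms with compound 1 but joins them differently; the difference between the two cores is not broken down here. In this assay compound 3 gives 42 ug/mL, a number that stands within the scatter of compound 1 and beyond it from compound 2.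

Compound 4, `COc1ccc(/C=C/c2cccc(O)c2)cc1`, is not yet measured. From compound 3 it differs by methoxy in place of amino on an aromatic carbon, the same kind of change as from compound 1 to compound 2, though here the place is para to the group of nine heavy atoms rather than ortho to it. Beside the earlier step, the step of a 1.7-fold lower number from compound 3 to compound 4 (0.23 log units; within the scatter) is expected, resting on the single observation that compound 2 gave 17 ug/mL against compound 1. Compound 4 is therefore estimated to give 25 ug/mL in this assay, within a range from 10 ug/mL to 60 ug/mL.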

Compound 4, half-maximal inhibitory concentration: 22 ug/mL
For compound 4 the middle estimate is 1.1-fold (0.06 log units) above the measured one; measured number inside the range.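

In this assay, methoxy in place of amino on an aromatic carbon gives a 1.9-fold lower number from compound 3 to compound 4 (0.28 log units; within the scatter), and the change carries from one core to the other at much the same size: the same change on two cores in this assay, a 1.8-fold lower number (0.25 log units; within the scatter) from compound 1 to compound 2 and a 1.9-fold lower number (0.28 log units; within the scatter) from compound 3 to compound 4, 1.1-fold (0.03 log units) apart, within the scatter of two such steps. On these two cores, then, the two steps cannot be told apart, and the same swap reads alike wherever the amino group stood in compound 1 and compound 3. This does not show that the swap itself has a real effect in this assay, as each step on its own lies within the scatter, and two pairs of compounds set no rule for other cores in the series.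

The compounds shown leave open how other groups would read at the same place, such as an ethoxy group, a carboxylic acid or a longer chain. They also leave open whether the swap would read alike on a core in which the hydroxyl on the other ring is replaced by a methoxy group.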